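This account rests on a few compounds, and the source may have more. Where it says the series, first, only, none or still open, it means among the compounds named here.

Going by the values given here, compound 1 `COc1ccc2c(c1)NC(=O)CN2c1nc(NCCCO)nc2ccccc12` is one of two compounds measured in a functional assay on KB cells (Homo sapiens) for inhibition, read by sulforhodamine B assay, with a stated time of 48 h; on this read-out higher numbers stand for weaker inhibition of growth and lower numbers for stronger inhibition of growth; in this assay compound 1 gives 4.92 nM, the lower of the two numbers. Compound 2 `COc1ccc2c(c1)NC(=O)CN2c1nc(Nc2ccc(C#N)cc2)nc2ccccc12` gives 5.39 nM in this assay, and the step of a 1.1-fold higher number from compound 1 to compound 2 (0.04 log units; within the scatter) lies within the scatter, so the two compounds cannot be placed in order. Compound 3 `COc1ccc2c(c1)NC(=O)CN2c1nc(COC(C)=O)nc2ccccc12` has not been measured. It differs from compound 1 in one place: acetoxymethyl in place of (3-hydroxypropyl)amino on an aromatic carbon. Among the compounds with values here, the only measured step, a 1.1-fold higher number from compound 1 to compound 2 (0.04 log units; within the scatter), exchanges one substituent on the amino nitrogen for another while keeping that nitrogen; the change to compound 3 removes the (3-hydroxypropyl)amino group itself, so no measured step bears on it directly, and the expected direction is uncertain. The estimate for compound 3 is 12 nM, with a range from 3 nM to 50 nM. This corresponds to an expected step of a 2.4-fold higher number from compound 1 to compound 3 (0.39 log units; beyond the scatter), only a little beyond the scatter.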

Compound 3, concentration for 50% growth inhibition in the KB assay: 5.05 nM
Compound 3: the middle estimate sits 2.4-fold (0.38 log units) above what was measured; the measured number falls inside the stated range.
By their numbers in the KB assay, from the lowest: compounds 1, 3 and 2 (each within the scatter of the next).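

In the KB assay, the aromatic carbon between two ring nitrogen atoms carries acetoxymethyl with no readable separation from the groups attached through nitrogen: a 1.0-fold higher number from compound 1 to compound 3 (0.01 log units; within the scatter), and a 1.1-fold lower number from compound 2 to compound 3 (0.03 log units; within the scatter). The earlier pair kept the linking nitrogen, whereas here it is gone and the 2 hydrogen-bond donors of (3-hydroxypropyl)amino give way to 0 in acetoxymethyl, yet the three numbers stay within the scatter of one another. In a physicochemical assay for lipophilicity, read by HPLC, measured as octanol-water partition, tested at 1 mg/mL (a lower number here means a more polar compound, a higher number a more lipophilic compound), compound 1 gives 2.6 and compound 3 gives 2.7, which also lie within the scatter.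

No evidence is available that accounts for these results. As far as these compounds go, whether a carboxylic acid, a primary amine or a longer chain at this carbon would keep the number in the KB assay within that same scatter remains open, so the limits of what this position accepts are not defined.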